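Working notes: chloro to methylsulfanyl swap in two cores

The compounds below may be only part of what the source reports. "The series", "measured", "known", "first", "only" and "open" are said of these compounds alone.

Measured so far, in a functional assay on the whole organism for inhibition, with Digitaria ciliaris as the target, with a stated time of 72 h, tested at 100 mg/L; a higher number here means more inhibition of growth at the concentration tested, a lower number less inhibition of growth:
compound 1 `COc1cc(SC)nc(NC(=S)NC(=O)c2c(-c3ccc(Cl)cc3Cl)noc2C)n1` gives 55.6%
compound 2 `COc1cc(Cl)nc(NC(=S)NC(=O)c2c(-c3ccc(Cl)cc3Cl)noc2C)n1` gives 62.2%
compound 3 `COc1cc(Cl)nc2n/c(=N/C(=O)c3c(-c4ccc(Cl)cc4Cl)noc3C)sn12` gives 72.8%

For the measured compounds named here, the single measured step is methylsulfanyl in place of chloro on an aromatic carbon, which gave a number 6.6 percentage points lower from compound 2 to compound 1 (within the scatter). Compound 3 stands highest of the three in this assay; the difference between its core and that of compound 2 is not broken down here.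

Compound 4 `COc1cc(SC)nc2n/c(=N/C(=O)c3c(-c4ccc(Cl)cc4Cl)noc3C)sn12` has not been measured. It differs from compound 3 by methylsulfanyl in place of chloro on an aromatic carbon. This is the same kind of change as between compound 2 and compound 1, not the same: in compound 3 the place is part of a fused or bridged system of two rings, meta to a fused ring and para to a fused ring, where in compound 2 it was meta to a large group.

For compound 4 the expected step is a number 5.8 percentage points lower from compound 3 to compound 4 (within the scatter), because a number 6.6 percentage points lower from compound 2 to compound 1 (within the scatter). Compound 4 is therefore expected to give 67%, estimated between 55% and 78%.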

Compound 4, percent growth inhibition at one concentration: 79.6%
Estimate against measurement, compound 4: 12.6 percentage points below; the measured number lies above the stated range.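

In this assay, methylsulfanyl in place of chloro gives a number 6.8 percentage points higher from compound 3 to compound 4 (within the scatter). Set beside the same change on the other core, this step does not separate from the earlier one: the same change on two cores in this assay, a number 6.6 percentage points lower (within the scatter) from compound 2 to compound 1 and a number 6.8 percentage points higher (within the scatter) from compound 3 to compound 4, 13.4 percentage points apart, within the scatter of two such steps. On these two pairs the change can be carried from one core to the other as a step that stays within the scatter, but the steps show no shared direction, and one pair per core cannot show whether the change has a real effect on either core.

The compounds shown leave open what an amine or a longer alkyl chain on the sulfur would give at this place. They also leave open whether either core would respond differently to such groups.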